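A few compounds are considered here, and "the series" means these few. Any claim that something is new, unique, unknown or untested is made for them only; others in the source may bear on it.

Measured so far:
Compound 1 `CCOc1cc(CN2CCC(NC(=O)c3ccc(NC(C)C)nc3)CC2)cc(OCC)c1F` — 7.84
Compound 2 `CCOc1cc(CN2CCC[C@@H](NC(=O)c3cncc(C)c3)CC2)cc(OCC)c1F` — "not determined" (no result reported)
Compound 3 `CCOc1cc(CN2CCC(NC(=O)c3ccc(N)nc3)CC2)ccc1C` — 8.27

In a physicochemical assay for acid dissociation, read by spectrophotometry, compound 1 gives 7.84, the lowest of the two numbers in hand. Compound 3 gives 8.27, a gap beyond the usual scatter, while compound 2 returned no number at all. The next compound, compound 4 `CCOc1cc(CN2CCC(NC(=O)c3ccc(NC)nc3)CC2)cc(OCC)c1F`, differs from compound 1 in a single spot: methyl in place of isopropyl on a nitrogen on an aromatic ring. Within the data shown here, no measured pair shows what this exact change does to the reading, so the expectation rests on the small size of the alteration, which touches neither a donor nor an acceptor count. The step from compound 1 to compound 4 is expected to be small, a number 0.06 log units higher from compound 1 to compound 4 (within the scatter), within the scatter in either direction. Compound 4 is therefore estimated at 7.9, between 7.5 and 8.3.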

Compound 4, acid dissociation constant: 7.83
Compound 4: the middle estimate sits 0.07 log units above what was measured; measured number inside the range.
By their numbers in this assay, from the lowest: compounds 4 and 1 (each within the scatter of the next); then compound 3.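

In this assay, among these compounds, methyl in place of isopropyl on a nitrogen on an aromatic ring gives a number 0.01 log units lower from compound 1 to compound 4 (within the scatter) and so provides the first comparison here of compounds that differ in one place. At this position, going from 3 heavy atoms to 1 leaves the two compounds indistinguishable by this reading. Nothing measured here accounts for that result. Going by these compounds, whether a larger or different group on this nitrogen, such as a cyclohexyl ring or an acetyl group, would separate from compound 1 remains open.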